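Three Chalcones Measured, a Fourth Estimated

The source may report more compounds than this note shows. Statements on the series, on what has been measured and on what is new or still open speak of the compounds shown alone.

Measured compounds:
compound 1, `COc1ccc(C(=O)/C=C/c2cn(-c3ccccc3)nc2-c2ccsc2)cc1OC`, 2900 nM
compound 2, `COc1ccc(OC)c(C(=O)/C=C/c2cn(-c3ccccc3)nc2-c2ccsc2)c1`, 2100 nM
compound 3, `COc1ccc(C(=O)/C=C/c2cn(-c3ccccc3)nc2-c2cccnc2)cc1OC`, 3100 nM

All three compounds were tested in a functional assay on Huh-7 cells (Homo sapiens) for inhibition, read by sulforhodamine B assay, with a stated time of 72 h; a higher number here means a weaker inhibitor, a lower number a stronger inhibitor. In this assay compound 1 gives 2900 nM, compound 2 gives 2100 nM, and compound 3 gives 3100 nM. The three numbers lie close together, and none of the steps between them is beyond the usual scatter of such a measurement.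

Compound 1 and compound 3 share one change, described as pyridin-3-yl in place of thiophen-3-yl on an aromatic carbon. The step that goes with it is a 1.1-fold higher number from compound 1 to compound 3 (0.03 log units; within the scatter), so the two cores behave alike here.

Compound 1 and compound 2 differ by 2,5-dimethoxyphenyl in place of 3,4-dimethoxyphenyl on a carbonyl carbon, and the step that goes with it is a 1.4-fold lower number from compound 1 to compound 2 (0.14 log units; within the scatter). The unmeasured compound 4, `COc1ccc(OC)c(C(=O)/C=C/c2cn(-c3ccccc3)nc2-c2cccnc2)c1`, differs from compound 3 by 2,5-dimethoxyphenyl in place of 3,4-dimethoxyphenyl on a carbonyl carbon. The place line of this change reads the same as for the change from compound 1 to compound 2, so it is the same change, made on the other core.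

Since the change from compound 1 to compound 2 gave a step within the scatter, the step from compound 3 to compound 4 is expected to be of similar size, namely a 1.4-fold lower number from compound 3 to compound 4 (0.15 log units; within the scatter). Among the measured compounds shown here, this expectation rests on only that one earlier pair, so it is weak. For compound 4 in this assay the estimated value is 2200 nM, with a range from 1100 nM to 4500 nM.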

Compound 4, half-maximal inhibitory concentration: 1300 nM
Compound 4: the middle estimate sits 1.7-fold (0.23 log units) above what was measured; measured number inside the range.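

In this assay, putting 2,5-dimethoxyphenyl in place of 3,4-dimethoxyphenyl on the carbonyl carbon gives a 2.4-fold lower number from compound 3 to compound 4 (0.38 log units; beyond the scatter), a modest step, and it still agrees with the earlier step for the same change on the other core: the same change on two cores in this assay, a 1.4-fold lower number (0.14 log units; within the scatter) from compound 1 to compound 2 and a 2.4-fold lower number (0.38 log units; beyond the scatter) from compound 3 to compound 4, 1.7-fold (0.24 log units) apart, within the scatter of two such steps. The swap of thiophen-3-yl for pyridin-3-yl, read on the cores that carry 2,5-dimethoxyphenyl, gives a 1.6-fold lower number from compound 2 to compound 4 (0.21 log units; within the scatter), and this too agrees with its earlier counterpart: the same change on two cores in this assay, a 1.1-fold higher number (0.03 log units; within the scatter) from compound 1 to compound 3 and a 1.6-fold lower number (0.21 log units; within the scatter) from compound 2 to compound 4, 1.7-fold (0.24 log units) apart, within the scatter of two such steps. Within what these measurements can resolve, each change therefore carries from one core to the other, but with only one pair of steps per change, this does not show that the dimethoxyphenyl swap truly counts for more on one core, nor that it would carry to any core beyond these two.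

The compounds shown leave open what other groups would do in place of the dimethoxyphenyl on the carbonyl carbon, such as a phenyl bearing a hydroxyl group or an amine. They also leave open what would happen if the phenyl shared by all four compounds were replaced, for example by a pyridine or a longer alkyl chain.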